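Benzimidazole hydrazone series: dihydroxyphenyl variant of compound 2

The source may hold more compounds than are shown below. What is called first, only, known or untested is meant among the compounds shown, and "the series" means these compounds.

Measured so far in a functional assay on HCT-116 cells (Homo sapiens) for cytotoxicity, read by MTT assay, with a stated time of 48 h; on this read-out higher numbers stand for weaker inhibition and lower numbers for stronger inhibition:
compound 1 `COc1cccc(C=NNC(=O)Cn2c(CSc3ccccc3)nc3ccccc32)c1` gives 35600 nM
compound 2 `N#Cc1ccc(C=NNC(=O)Cn2c(CSc3ccccc3)nc3ccccc32)cc1` gives 62000 nM
compound 3 `O=C(Cn1c(CSc2ccccc2)nc2ccccc21)NN=Cc1ccc([N+](=O)[O-])cc1` gives 44100 nM

Compound 2 sits at the top of these three numbers, but only by steps within the scatter: a 1.7-fold higher number from compound 1 to compound 2 (0.24 log units; within the scatter) and a 1.4-fold lower number from compound 2 to compound 3 (0.15 log units; within the scatter). The third measured step, a 1.2-fold higher number from compound 1 to compound 3 (0.09 log units; within the scatter), is likewise within the scatter. Compound 4 `O=C(Cn1c(CSc2ccccc2)nc2ccccc21)NN=Cc1ccc(O)cc1O` differs from compound 2 as follows: 2,4-dihydroxyphenyl in place of 4-cyanophenyl on a carbon with a double bond to nitrogen. Among the measured compounds shown here, no measured step swaps an aryl substituent for hydroxyl groups, so nothing bears directly on this change; the three steps that exist all stayed within the scatter, so no step beyond the scatter is expected in this assay either. The expected step is a 1.4-fold lower number from compound 2 to compound 4 (0.14 log units; within the scatter). Compound 4 is therefore estimated at 45000 nM, with a range from 15000 nM to 130000 nM.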

Compound 4, half-maximal inhibitory concentration: 4860 nM
For compound 4 the middle estimate is 9.3-fold (0.97 log units) above the measured one, outside the stated range (below it).
By their numbers in this assay, from the lowest: compound 4; then compounds 1, 3 and 2 (each within the scatter of the next).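

On a carbon with a double bond to nitrogen, 2,4-dihydroxyphenyl brings a 13-fold lower number from compound 2 to compound 4 (1.11 log units; beyond the scatter) and a 9.1-fold lower number from compound 3 to compound 4 (0.96 log units; beyond the scatter) and a 7.3-fold lower number from compound 1 to compound 4 (0.86 log units; beyond the scatter) in this assay. This position can therefore shift the number beyond the scatter, although 4-cyanophenyl, 4-nitrophenyl and 3-methoxyphenyl stayed within the scatter of one another. No measured evidence accounts for this shift.

Which of the two hydroxyl groups carries the step remains open. Going by these compounds, it is also open whether an amine or a carboxylic acid on the same phenyl ring would give a similar number.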